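This account rests on a few compounds, and the source may have more. Where it says the series, first, only, none or still open, it means among the compounds named here.

Measured so far:
Compound 1 `COC(=O)C1=C(C)N=C(C)/C(=C(\O)OC)C1c1cccc(C(F)(F)F)c1`: 74.1 nM
Compound 2 `COC(=O)C1=C(C)N=C(C)/C(=C(\O)OC)C1c1cc(C)ccc1C`: 100 nM

Both compounds were tested in a functional assay (muscle tissue) with Cavia porcellus as the target; on this read-out lower numbers stand for an effect already at smaller amounts and higher numbers for an effect only at larger amounts of compound. Compound 2 gives 100 nM and compound 1 gives 74.1 nM. These two numbers lie within the usual scatter of repeated measurements, so they cannot be ranked, and compound 2 stands level with compound 1 on the evidence so far.

Compound 3 `COC(=O)C1=C(C)N=C(C)/C(=C(\O)OC)C1c1cccc(F)c1` keeps the shared core and carries 3-fluorophenyl in place of 2,5-dimethylphenyl on a saturated ring carbon. For the measured compounds named here, no measured pair yet isolates a single change at this place, so the guide is thin. Still, compound 1 at 74.1 nM and compound 2 at 100 nM carry different groups here and remain within the scatter of each other. In this assay, no shift beyond the scatter is therefore expected, and no direction can be favoured. The expected step is a 1.2-fold lower number from compound 2 to compound 3 (0.07 log units; within the scatter). For compound 3 the estimate is 85 nM, with an expected range of 25 nM to 290 nM.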

Compound 3, half-maximal effective concentration: 20.9 nM
For compound 3 the middle estimate is 4.1-fold (0.61 log units) above the measured one, and the stated range ends above it.
By their numbers in this assay, from the lowest: compound 3; then compounds 1 and 2 (each within the scatter of the next).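

In this assay, the group on the saturated ring carbon clearly matters: 3-fluorophenyl in place of 2,5-dimethylphenyl gives a 4.8-fold lower number from compound 2 to compound 3 (0.68 log units; beyond the scatter). Compounds 1 and 2 could not show this, since their values lie within the scatter of each other and the different groups they carry seemed to make no measurable difference. The closest comparison is fluoro in place of trifluoromethyl on an aromatic carbon, a change in one small part of the aryl group that gives a 3.5-fold lower number from compound 1 to compound 3 (0.55 log units; beyond the scatter), so that compound 3 now has the lowest number of the three and an effect appears at smaller amounts of compound.

As far as these compounds go, three aryl groups are too few to give a trend, so it remains open how plain phenyl, or a phenyl ring carrying a chloro, nitrile or methoxy group, would compare with 3-fluorophenyl at this place. Nothing available here offers any measured explanation for the lower number of compound 3.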